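The compounds below may be only part of what the source reports. "The series", "measured", "known", "first", "only" and "open" are said of these compounds alone.

Of the compounds shown here, three built on one shared core have been measured: compound 1 `Cn1c(-c2ccc(NC(=O)CSc3nc4cc(Cl)ccc4o3)cc2)nc(-c2ccccc2)c1-c1ccccc1`, compound 2 `Cc1ccc2oc(SCC(=O)Nc3ccc(-c4nc(-c5ccccc5)c(-c5ccccc5)n4C)cc3)nc2c1` and compound 3 `Cn1c(-c2ccc(NC(=O)CSc3nc4ccccc4s3)cc2)nc(-c2ccccc2)c1-c1ccccc1`. In a functional assay on HT-29 cells (Homo sapiens) for cytotoxicity, read by MTT assay, with a stated time of 24 h, tested at 6.4 ug/mL (on this read-out higher numbers stand for a stronger effect at the one concentration tested and lower numbers for a weaker effect), compound 1 gives 29.4% and compound 2 gives 25.6%. Compound 3 gives 36.8% in this assay; the step of a number 11.2 percentage points higher from compound 2 to compound 3 (beyond the scatter) lies beyond the scatter, whereas compound 1 and compound 3 lie within the scatter of each other. Compound 4 `Cn1ccnc1SCC(=O)Nc1ccc(-c2nc(-c3ccccc3)c(-c3ccccc3)n2C)cc1` differs from compound 3 in one place: 1-methyl-1H-imidazol-2-yl in place of 1,3-benzothiazol-2-yl on a sulfur. Going by the values given here, the steps that touch this sulfur are a number 7.4 percentage points higher from compound 1 to compound 3 (within the scatter) and a number 11.2 percentage points higher from compound 2 to compound 3 (beyond the scatter), both exchanges between groups that keep a six-membered aromatic ring of carbon only; a move to a group with only one five-membered aromatic ring has no measured counterpart. A modest fall is expected, a number 8.8 percentage points lower from compound 3 to compound 4 (within the scatter), within the scatter. Compound 4 is therefore estimated at 28%, in a range from 15% to 42%.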

Compound 4, a percentage reported as activity, at one concentration (the size of the read-out at that concentration, not a potency): 30.7%
Beside the measured number, compound 4's estimate is 2.7 percentage points below it, within the range that was stated.
By their numbers in this assay, from the lowest: compounds 2, 1, 4 and 3 (each within the scatter of the next, the first and the last beyond it).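

In this assay, 1-methyl-1H-imidazol-2-yl in place of 1,3-benzothiazol-2-yl on the sulfur removes the six-membered aromatic ring of carbon only and gives a number 6.1 percentage points lower from compound 3 to compound 4 (within the scatter), so the read-out at this position does not depend on that ring. Against the other two groups on this sulfur, the steps are a number 5.1 percentage points higher from compound 2 to compound 4 (within the scatter) and a number 1.3 percentage points higher from compound 1 to compound 4 (within the scatter), so 1-methyl-1H-imidazol-2-yl stands apart from none of the three. Nothing on hand explains this result. Going by these compounds, whether a saturated amine such as piperidine or a carboxylic acid on a longer chain would hold this read-out on the sulfur remains open. On these data alone, with a single tested concentration, potency also remains open.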